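The compounds below may be only part of what the source reports. "The series", "measured", "known", "first", "only" and "open" are said of these compounds alone.

Measured compounds in an assay on cells for inhibition of steroid 17-alpha-hydroxylase/17,20 lyase (Homo sapiens), read by scintillation counting, with stated times of 60 min and 4 h; on this read-out higher numbers stand for weaker inhibition and lower numbers for stronger inhibition:

Compound 1 `O=S(=O)(C1CC1)N1CCN(c2ccc(/C=C/c3cc(F)cc(Cn4ccnc4)c3)cc2)CC1` gives 34 nM.
Compound 2 `O=S(=O)(C(F)F)N1CCN(c2ccc(/C=C/c3cc(Cl)cc(-c4ccncc4)c3)cc2)CC1` gives 5 nM.
Compound 3 `O=S(=O)(C1CC1)N1CCN(c2ccc(/C=C/c3cc(F)cc(-c4ccncc4)c3)cc2)CC1` gives 1 nM.

Among these three, compound 3 stands at the lowest number in this assay and is therefore the strongest inhibitor of the set; its nearest neighbour is compound 2, and compound 1 lies furthest away. Going by the values given here, the one single-point step seen so far, a 34-fold lower number from compound 1 to compound 3 (1.53 log units; beyond the scatter), is large, but it concerns a change on the aromatic ring, not on the sulfonyl group, so it says nothing direct about what follows.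

Compound 4 `O=S(=O)(N1CCN(c2ccc(/C=C/c3cc(F)cc(-c4ccncc4)c3)cc2)CC1)C(F)(F)F` is the next compound to be measured. It differs from compound 3 in one place: trifluoromethyl in place of cyclopropyl on a sulfonyl sulfur. Among the compounds with values here, compound 2 also carries a fluorinated group on its sulfonyl sulfur, yet it differs from compound 3 in a second place as well, so the two values of compound 2 and compound 3 in this assay show only that a fluorinated sulfonyl group can sit on this core while the number stays in the low range. Within the data shown here, no measured step isolates the change from cyclopropyl to trifluoromethyl, so the expectation rests on that loose comparison alone: the step of a 2.0-fold higher number from compound 3 to compound 4 (0.30 log units; within the scatter) is expected to be small, within or just beyond the scatter, in either direction. Compound 4 is estimated at 2 nM, with a range from 0.7 nM to 6 nM.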

Compound 4, half-maximal inhibitory concentration: 2 nM
Compound 4: the middle estimate sits on the measured number at the digits printed; the range from low to high includes it.
By their numbers in this assay, from the lowest: compounds 3 and 4 (each within the scatter of the next); then compound 2; then compound 1.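

In this assay, the step of a 2.0-fold higher number from compound 3 to compound 4 (0.30 log units; within the scatter) is the first comparison shown that isolates the group on the sulfonyl sulfur, with the rest of the structure held the same. Cyclopropyl, a three-membered ring of carbon, and trifluoromethyl, which has no ring and carries fluorine, cannot be told apart on this read-out, so a carbon ring at this position is not required to keep the number in the low range. No measurement shown here accounts for the two groups reading alike.

Going by these compounds alone, only this pair can be compared directly on an otherwise identical structure, so it remains open what a methyl group, a longer chain such as n-butyl, or an amine such as dimethylamino would give on the sulfonyl sulfur. On these data alone, it also remains open whether exchanging cyclopropyl for trifluoromethyl would read the same with (1H-imidazol-1-yl)methyl in place of pyridin-4-yl on the aromatic carbon, the group carried by compound 1.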